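Acyl cap exchange at two chain lengths

The compounds below may be only part of what the source reports. "The series", "measured", "known", "first", "only" and "open" are said of these compounds alone.

Measured so far:
compound 1 `CCCCCCCCCCCCNC(=O)[C@@H](NC(=O)c1cc2ccccc2n1C)[C@@H](C)O` gives 31300 nM
compound 2 `CCCCCCCCCCCCNC(=O)[C@@H](NC(=O)/C=C/c1ccccc1)[C@@H](C)O` reaches only a limit of the assay, > 200000 nM
compound 3 `CCCCCCCCCCCCCCNC(=O)[C@@H](NC(=O)c1cc2ccccc2n1C)[C@@H](C)O` gives 25700 nM

In a functional assay on MCF7 cells (Homo sapiens) for cytotoxicity, read by MTT assay, with a stated time of 48 h (on this read-out lower numbers stand for stronger inhibition and higher numbers for weaker inhibition), compound 1 gives 31300 nM. Compound 3 gives 25700 nM, and the step of a 1.2-fold lower number from compound 1 to compound 3 (0.09 log units; within the scatter) is within the scatter. The two cores differ by ethyl in place of hydrogen on a saturated chain carbon, ten or more bonds along the chain from an amide-type nitrogen.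

Compound 2 returns a limit of the assay, > 200000 nM, and nothing more. The step of an at least 6.3-fold higher number from compound 1 to compound 2 (0.80 log units; beyond the scatter) comes from the change (2-phenylethenyl in place of 1-methyl-1H-indol-2-yl on a carbonyl carbon).

Compound 4 `CCCCCCCCCCCCCCNC(=O)[C@@H](NC(=O)/C=C/c1ccccc1)[C@@H](C)O` is not yet measured. It differs from compound 3 by 2-phenylethenyl in place of 1-methyl-1H-indol-2-yl on a carbonyl carbon, the same change at the same place as from compound 1 to compound 2. A step of similar size, a 7.8-fold higher number from compound 3 to compound 4 (0.89 log units; beyond the scatter), is expected because an at least 6.3-fold higher number from compound 1 to compound 2 (0.80 log units; beyond the scatter) was at least that large on the shorter chain. Compound 4 is thus expected at 200000 nM in this assay, in the range 80000 nM to 400000 nM, most likely reported only as a limit.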

Compound 4, half-maximal inhibitory concentration: 64600 nM
Compound 4: the middle estimate sits 3.1-fold (0.49 log units) above what was measured; measured number below the stated range.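

In this assay, exchanging 1-methyl-1H-indol-2-yl for 2-phenylethenyl on the carbonyl carbon gives a 2.5-fold higher number from compound 3 to compound 4 (0.40 log units; beyond the scatter), so the direction seen on the shorter chain carries over to the longer one, though equal size is not shown: the same change on two cores in this assay, an at least 6.3-fold higher number (0.80 log units; beyond the scatter) from compound 1 to compound 2 and a 2.5-fold higher number (0.40 log units; beyond the scatter) from compound 3 to compound 4; the limit leaves it open whether they differ

The ethyl extension of the chain gives an at least 3.0-fold lower number from compound 2 to compound 4 (0.49 log units; beyond the scatter) with 2-phenylethenyl in place, but this does not show that chain length matters more with this group than with 1-methyl-1H-indol-2-yl: the same change on two cores in this assay, a 1.2-fold lower number (0.09 log units; within the scatter) from compound 1 to compound 3 and an at least 3.0-fold lower number (0.49 log units; beyond the scatter) from compound 2 to compound 4; the limit leaves it open whether they differ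

Going by these compounds, compound 2 gives only a limit of the assay, > 200000 nM, and its true position remains unknown.

Within the data shown here, the series shows this change on only two cores, so no general rule for carrying it to other cores follows. Still open, on these data alone, are whether the direction holds on a still longer chain, and whether it holds when the chain carries an amine or a carboxylic acid.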